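Dropping the amino group from compound 2

This account rests on a few compounds, and the source may have more. Where it says the series, first, only, none or still open, it means among the compounds named here.

Measured so far in a functional assay on MDA-MB-435 cells (Homo sapiens) for inhibition, read by sulforhodamine B assay, with a stated time of 48 h; on this read-out higher numbers stand for weaker inhibition and lower numbers for stronger inhibition
Compound 1 (`Cc1ccc(N(C)c2ncnc3c2CCC3)cc1`) gives "not determined" (no result reported)
Compound 2 (`CCOc1ccc(N(C)c2nc(N)nc3c2CCC3)cc1`) gives 20.3 nM

Among the compounds with values here, compound 2 holds the only number so far, so it cannot yet be ranked against anything. Compound 1 has no result and offers no comparison.

The next compound to be read is compound 3 (`CCOc1ccc(N(C)c2ncnc3c2CCC3)cc1`). It differs from compound 2 in a single place: hydrogen in place of amino on an aromatic carbon (hydrogen in place of amino on an aromatic carbon, between two ring nitrogen atoms). Within the data shown here, no measured pair shows what this change does in this assay, so the expectation rests only on compound 2 at 20.3 nM and on the structural change itself. Both the size and the direction remain uncertain. A modest weakening of inhibition is expected, and a result within the usual scatter would not be surprising. The estimated change is a 2.0-fold higher number from compound 2 to compound 3 (0.29 log units; within the scatter) (a tentative figure). Compound 3 is expected to read 40 nM (estimated range 8 nM to 200 nM).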

Compound 3, half-maximal inhibitory concentration: 48.7 nM
For compound 3 the middle estimate is 1.2-fold (0.09 log units) below the measured one; the measured number falls inside the stated range.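

In this assay the series now has its first measured pair, and it gives a 2.4-fold higher number from compound 2 to compound 3 (0.38 log units; beyond the scatter). Hydrogen in place of amino on this aromatic carbon, between two ring nitrogen atoms, therefore weakens inhibition modestly, yet the amino group is not required for activity in the nanomolar range: without it, compound 3 still reads 48.7 nM in this assay. The reading rests on this single pair, and nothing at hand gives a reason for the size of this step.

Still open, from the compounds shown here alone, is how other groups at this same position would read against amino and hydrogen, for instance methyl, methoxy, chlorine or a dimethylamino group, and whether any of them would go below the number of compound 2. Going by these compounds, the ethoxy group on compound 3 also cannot be judged against the methyl group of compound 1, which stands without a result, so whether the effect of removing amino holds with other groups in that place remains unknown as well.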